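The source may hold more compounds than are shown below. What is called first, only, known or untested is meant among the compounds shown, and "the series" means these compounds.

Compound 1 `Cc1ccc(CC(CNC(=S)NCc2ccc(NS(C)(=O)=O)c(F)c2)COC(=O)C(C)(C)C)cc1C`: 7.8 nM
Compound 2 `Cc1ccc(CC(COC(=O)C(C)(C)C)CN(O)/C(S)=N/Cc2ccc(NS(C)(=O)=O)c(F)c2)cc1C`: 94 nM
Compound 3 `Cc1ccc(CC(CNC(=S)OCc2ccc(NS(C)(=O)=O)cc2)COC(=O)C(C)(C)C)cc1C`: 440 nM

In a functional assay on CHO cells for antagonist activity at transient receptor potential cation channel subfamily V member 1 (Rattus norvegicus) (a lower number here means a stronger inhibitor, a higher number a weaker inhibitor), compound 3 gives the highest of the three numbers; its nearest neighbour is compound 2 and its furthest compound 1, and both gaps lie beyond the scatter. Compound 4 `Cc1ccc(CC(CNC(=S)OCc2ccc(NS(C)(=O)=O)c(F)c2)COC(=O)C(C)(C)C)cc1C` is compound 3 with fluoro in place of hydrogen on an aromatic carbon, placed ortho to the methanesulfonamido group. Going by the values given here, no measured pair shows this change on its own, so its size is uncertain. Compounds 1 and 2 both carry the fluoro and both sit well below compound 3, though they differ from it elsewhere too. A modest gain in this assay is expected, close to the edge of the scatter. For compound 4 the expected step is a 2.9-fold lower number from compound 3 to compound 4 (0.47 log units; beyond the scatter), giving an estimate of 150 nM, ranging from 50 nM to 450 nM.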

Compound 4, half-maximal inhibitory concentration: 170 nM
For compound 4 the middle estimate is 1.1-fold (0.05 log units) below the measured one, within the range that was stated.
By their numbers in this assay, from the lowest: compound 1; then compounds 2 and 4 (each within the scatter of the next); then compound 3.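

In this assay, going by these compounds alone, fluoro in place of hydrogen, ortho to a methanesulfonamido group, is seen on its own for the first time, and it gives a 2.6-fold lower number from compound 3 to compound 4 (0.41 log units; beyond the scatter) as the only change. The earlier compounds shown here carried this fluoro only alongside other differences, so this single atom now has a size of its own at this position. Nothing available accounts for the gain. As far as these compounds go, whether chloro or methoxy at this position would give a similar step remains open, as does the size of the fluoro step on the core of compound 1.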